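Notes on a three-compound set and one unmeasured analogue

A few compounds are considered here, and "the series" means these few. Any claim that something is new, unique, unknown or untested is made for them only; others in the source may bear on it.

In a functional assay on the whole organism with Rattus norvegicus as the target, at a dose of 20 mg/kg by the intraperitoneal route (a higher number here means more inhibition at the dose given (going by the name of the read-out), a lower number less inhibition), the measured compounds give the following:
compound 1 `CS(=O)(=O)c1cccc(-c2nc(N)nc(N)n2)c1`: -6%
compound 2 `CCOc1ccccc1-c1nc(N)nc(N)n1`: -5%
compound 3 `COc1ccccc1-c1nc(N)nc(N)n1`: 1%

Compound 1 carries the lowest of the three numbers, but the gaps to compound 2 and to compound 3 both lie within the usual scatter, so the three compounds cannot be separated on these numbers. For the measured compounds named here, the single step between compounds that differ in one place, a number 6 percentage points higher from compound 2 to compound 3 (within the scatter), concerns hydrogen in place of methyl on a saturated chain carbon bound to an oxygen on an aromatic ring and is itself within the scatter.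

Compound 4 `Nc1nc(N)nc(-c2cccc([N+](=O)[O-])c2)n1` is not yet measured. Compared with compound 1 it shows (nitro in place of methylsulfonyl on an aromatic carbon). Going by the values given here, no measured step touches a change at this position or of this kind, so nothing in the set argues for a move in either direction, and every measured number sits near zero.

Compound 4 is therefore expected to show a number 4 percentage points higher from compound 1 to compound 4 (within the scatter), a step not beyond the scatter. The estimate for compound 4 in this assay is -2%, with a range from -16% to 12%.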

Compound 4, a percentage reported as inhibition, in the whole organism at one dose (the size of the read-out at that dose, not a potency): 85%
Estimate against measurement, compound 4: 87 percentage points below; measured number outside the range, above it.
By their numbers in this assay, from the lowest: compounds 1, 2 and 3 (each within the scatter of the next); then compound 4.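

In this assay, for the compounds shown here, nitro in place of methylsulfonyl on an aromatic carbon gives a number 91 percentage points higher from compound 1 to compound 4 (beyond the scatter) and is the only step in the set beyond the scatter. This place on the ring can therefore decide between no measurable inhibition and strong inhibition at the dose given, which compounds 1, 2 and 3 could not show while their numbers stayed within the scatter of one another. Nothing measured here explains why this exchange has so large an effect.

Going by these compounds, it remains open whether the high number is specific to nitro or would also appear with an amine, a carboxylic acid or a nitrile in the same place. A reading at a single dose also leaves open how potent compound 4 is and whether nitro elsewhere on the ring would give a similar number.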